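The compounds below may be only part of what the source reports. "The series", "measured", "known", "first", "only" and "open" are said of these compounds alone.

Of the compounds shown here, three built on a shared core have been tested in an assay for inhibition of Alpha amylase (Homo sapiens), with a stated time of 10 min; a lower number here means a stronger inhibitor, a higher number a weaker inhibitor. Compound 1, whose structure is `COc1ccc(-c2nc3cc(Cl)ccc3[nH]2)c(F)c1`, gives 2740 nM. Compound 3, with the structure `COc1ccc(-c2nc3cc([N+](=O)[O-])ccc3[nH]2)c(F)c1`, differs from compound 1 only by nitro in place of chloro on an aromatic carbon, and in this assay compound 3 gives 2750 nM. The step of a 1.0-fold higher number from compound 1 to compound 3 (0.00 log units; within the scatter) shows that swapping these two groups left the inhibition essentially unchanged in that pair.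

Compound 2, with the structure `COc1cc(-c2nc3cc(Cl)ccc3[nH]2)cc(I)c1O`, carries a different outer ring, and the difference between its core and the core of compound 1 is not broken down here. In this assay compound 2 gives 1610 nM, a number that sits within the usual scatter of both compound 1 and compound 3, so no ordering among the three can be claimed.

Compound 4, with the structure `COc1cc(-c2nc3cc([N+](=O)[O-])ccc3[nH]2)cc(I)c1O`, has not yet been measured. Its relation to compound 2 is nitro in place of chloro on an aromatic carbon, the same change that was already made from compound 1 to compound 3, at the same place on the core. Because a 1.0-fold higher number from compound 1 to compound 3 (0.00 log units; within the scatter) was flat, the same step is expected for compound 4 as a 1.0-fold lower number from compound 2 to compound 4 (0.00 log units; within the scatter). Compound 4 is therefore estimated to give about 1600 nM in this assay. The expected range for compound 4 runs from 700 nM to 3700 nM, resting on a single earlier example of this change.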

Compound 4, half-maximal inhibitory concentration: 1720 nM
Compound 4: middle estimate off by 1.1-fold (0.03 log units), on the low side; low and high end bracket the measured number.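

In this assay, putting nitro in place of chloro on the core of compound 2 gives a 1.1-fold higher number from compound 2 to compound 4 (0.03 log units; within the scatter). Set beside the earlier case, the change behaves alike on both cores: the same change on two cores in this assay, a 1.0-fold higher number (0.00 log units; within the scatter) from compound 1 to compound 3 and a 1.1-fold higher number (0.03 log units; within the scatter) from compound 2 to compound 4, 1.1-fold (0.03 log units) apart, within the scatter of two such steps. This shows that, for these two pairs, the swap left the number flat whichever of the two cores carried it, so the earlier step was a fair guide here; it does not show that the same would hold on any other core, in any other assay, or at any other place on the ring, and it gives no reason why chloro and nitro read alike.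

The compounds shown have only chloro or nitro at this place, which leaves open whether another group there, such as an amine, a carboxylic acid or a longer chain, would shift the number beyond the scatter. For the compounds shown here, only two outer rings appear in these pairs, and both steps are flat, so it also remains open whether a core can alter the size of a change that has a clear effect on inhibition.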